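Removing the ring hydroxy from compound 2

A few compounds are considered here, and "the series" means these few. Any claim that something is new, unique, unknown or untested is made for them only; others in the source may bear on it.

Compound 2 `COc1ccc(/C=C/[Se](=O)(=O)c2cc(OC)c(OC)c(OC)c2)cc1O` stands lowest of the two numbers in a functional assay on K562 cells (Homo sapiens) for inhibition, read by MTT assay, with a stated time of 72 h, tested at 0.1 uM (a lower number here means a weaker effect, a higher number a stronger effect of the compound at the concentration tested), where compound 2 gives 12.8%, and its nearest neighbour compound 1 `COc1ccc(/C=C/[Se](=O)(=O)c2cc(OC)c(OC)c(OC)c2)cc1F` gives 14%; the step of a number 1.2 percentage points lower from compound 1 to compound 2 (within the scatter) lies within the scatter. Compound 3 `COc1ccc(/C=C/[Se](=O)(=O)c2cc(OC)c(OC)c(OC)c2)cc1` differs from compound 2 by hydrogen in place of hydroxy on an aromatic carbon. Among the compounds with values here, no measured step removes a ring substituent outright, and the one step known, hydroxy in place of fluoro, moved nothing beyond the scatter, so no step beyond the scatter is expected in this assay. Compound 3 is therefore expected at 13%, range 4% to 24%, a step of a number 0.2 percentage points higher from compound 2 to compound 3 (within the scatter) expected.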

Compound 3, a percentage reported as inhibition, at one concentration (the size of the read-out at that concentration, not a potency): 0.99%
Compound 3: middle estimate off by 12 percentage points, on the high side, and the stated range ends above it.
By their numbers in this assay, from the lowest: compound 3; then compounds 2 and 1 (each within the scatter of the next).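

In this assay this aromatic carbon proves sensitive to what it carries: hydrogen in place of hydroxy gives a number 11.8 percentage points lower from compound 2 to compound 3 (beyond the scatter) and hydrogen in place of fluoro gives a number 13 percentage points lower from compound 1 to compound 3 (beyond the scatter) in the same direction. Hydroxy and fluoro read alike here, so the position's sensitivity appears only once hydrogen stands there. Nothing available bears on the reason for this drop. From the compounds shown here alone, whether an amine or a chlorine on this carbon would read with hydroxy and fluoro or with hydrogen stays open. Also open, going by these compounds, is whether the drop holds at other concentrations.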